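Swapping the Sulfonyl Aryl Group: Methyl Out, Fluorine In

This account rests on a few compounds, and the source may have more. Where it says the series, first, only, none or still open, it means among the compounds named here.

Of the compounds shown here, three have been measured in a functional assay on A2780 cells (Homo sapiens) for inhibition, read by sulforhodamine B assay, with a stated time of 72 h; on this read-out lower numbers stand for stronger inhibition and higher numbers for weaker inhibition. Compound 1 `Cc1cccc(S(=O)(=O)c2ccc(CNC(=O)c3cc4cnccc4[nH]3)cc2)c1` gives 4 nM, the lowest of the three numbers. Compound 3 `O=C(NCc1ccc(S(=O)(=O)c2ccccc2)cc1)c1ccc2nccn2c1` gives 13 nM, and compound 2 `O=C(NCc1ccc(S(=O)(=O)N2CCCCC2)cc1)c1cc2ccncc2[nH]1` gives 1700 nM; each of these is higher than compound 1, and each gap is beyond the scatter of repeated measurements. Compound 4 `O=C(NCc1ccc(S(=O)(=O)c2ccc(F)cc2)cc1)c1cc2cnccc2[nH]1` has not yet been measured. It differs from compound 1 by 4-fluorophenyl in place of 3-methylphenyl on a sulfonyl sulfur. Going by the values given here, no pair of measured compounds shows this change on its own, so there is no step from which to read its size. The expected step is a 1.5-fold higher number from compound 1 to compound 4 (0.18 log units; within the scatter), small and within the scatter, in either direction. Compound 4 is therefore expected to give about 6 nM, estimated between 2 nM and 20 nM.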

Compound 4, half-maximal inhibitory concentration: 16 nM
Estimate against measurement, compound 4: 2.7-fold (0.43 log units) below; the range from low to high includes it.
By their numbers in this assay, from the lowest: compound 1; then compounds 3 and 4 (each within the scatter of the next); then compound 2.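

In this assay, the aryl group on the sulfonyl sulfur proves to matter on this core: 4-fluorophenyl in place of 3-methylphenyl gives a 4.0-fold higher number from compound 1 to compound 4 (0.60 log units; beyond the scatter). Going by these compounds alone, the step is modest, but it is the first one read at this position, and both groups are carbon-only aromatic rings. Nothing shown here accounts for the step.

The compounds shown leave open whether the step follows from the methyl leaving or the fluorine entering. They also leave open how an amine or a carboxylic acid on this aryl ring would read.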